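This account rests on a few compounds, and the source may have more. Where it says the series, first, only, none or still open, it means among the compounds named here.

Compound 2 `COc1ccc(C(=O)Nc2c(F)cccc2Cl)cc1OC1CCCC1` gives 240 nM in an assay on isolated protein for inhibition of phosphodiesterase 4A (Sus scrofa) (a lower number here means a stronger inhibitor, a higher number a weaker inhibitor), and so stands at the highest of the two numbers measured; its nearest neighbour, compound 1 `COc1ccc(C(=O)Nc2ccccc2Br)cc1OC1CCCC1`, gives 130 nM, and the step of a 1.8-fold higher number from compound 1 to compound 2 (0.27 log units; within the scatter) lies within the scatter. Compound 3 `COc1ccc(C(=O)Nc2ccncc2Cl)cc1OC1CCCC1` is still to be measured. The change is 3-chloropyridin-4-yl in place of 2-chloro-6-fluorophenyl on an amide-type nitrogen. Going by the values given here, the only measured step, from compound 1 to compound 2, swaps one substituted phenyl for another and does not bring in a ring nitrogen, so it bears on this change only loosely. No step beyond the scatter is therefore expected, and compound 3 is estimated at 200 nM, range 70 nM to 600 nM, meaning an expected step of a 1.2-fold lower number from compound 2 to compound 3 (0.08 log units; within the scatter).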

Compound 3, half-maximal inhibitory concentration: 16 nM
Compound 3: middle estimate off by 13-fold (1.10 log units), on the high side; the measured number lies below the stated range.
By their numbers in this assay, from the lowest: compound 3; then compounds 1 and 2 (each within the scatter of the next).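

On the amide-type nitrogen, 3-chloropyridin-4-yl stands apart from both phenyl groups in this assay, with a 15-fold lower number from compound 2 to compound 3 (1.18 log units; beyond the scatter) and an 8.1-fold lower number from compound 1 to compound 3 (0.91 log units; beyond the scatter). The earlier exchange of one phenyl group for another stayed within the scatter, so only the entry of the ring with a hetero atom shows that this position can respond strongly. Nothing measured here explains the step.

Open, going by these compounds, is whether the ring nitrogen or the chlorine carries this step. Also open, on these data alone, is how a methoxy or a nitrile in place of that chlorine would read.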